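This account rests on a few compounds, and the source may have more. Where it says the series, first, only, none or still open, it means among the compounds named here.

Three compounds were measured in a physicochemical assay for lipophilicity; on this read-out higher numbers stand for higher lipophilicity and lower numbers for lower lipophilicity. Compound 2 `CCCCCCCCCCCCNCCCN` gives 5.06. Compound 1 `CCCCCCCCCCCCNCCO` gives 3.93; it differs from compound 2 by hydroxy in place of aminomethyl on a saturated chain carbon, two bonds along the chain from an amine nitrogen, and that change gave a number 1.13 log units lower from compound 2 to compound 1 (beyond the scatter). Compound 3 `CCCCCCCCCCNCCCN` gives 2.82; it differs from compound 2 by hydrogen in place of ethyl on a saturated chain carbon, ten or more bonds along the chain from an amine nitrogen, a change in the shared core that gave a number 2.24 log units lower from compound 2 to compound 3 (beyond the scatter).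

Compound 4 `CCCCCCCCCCNCCO` is not yet measured. It differs from compound 3 by hydroxy in place of aminomethyl on a saturated chain carbon, two bonds along the chain from an amine nitrogen, the same change as from compound 2 to compound 1, at the same place. Because that change gave a number 1.13 log units lower from compound 2 to compound 1 (beyond the scatter) on the core of compound 2, a step of similar size is expected on the core of compound 3, namely a number 1.13 log units lower from compound 3 to compound 4 (beyond the scatter). Compound 4 is therefore estimated at 1.69, with a likely range from 1.2 to 2.2.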

Compound 4, partition coefficient: 3.09
Beside the measured number, compound 4's estimate is 1.40 log units below it; measured number outside the range, above it.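

In this assay hydroxy in place of aminomethyl gave a number 1.13 log units lower from compound 2 to compound 1 (beyond the scatter) on one core but a number 0.27 log units higher from compound 3 to compound 4 (within the scatter) on the other, so the step did not carry over between these two cores. Read the other way, hydrogen in place of ethyl gave a number 2.24 log units lower from compound 2 to compound 3 (beyond the scatter) with aminomethyl present and a number 0.84 log units lower from compound 1 to compound 4 (beyond the scatter) with hydroxy present, so the two changes do not simply add up here. This is a single pair of cores and shows no rule for the whole series, and nothing measured here explains the mismatch.

The compounds shown leave open what a carboxylic acid or a methoxy group would give in the same place on either core. They also leave open how either step would look on a longer chain.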